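Branching the Alkoxy Chain: Pentyloxy to Isopentyloxy

This account rests on a few compounds, and the source may have more. Where it says the series, first, only, none or still open, it means among the compounds named here.

Measured compounds:
compound 1, `CCCCOc1cc(C(=O)N(C)C)nn1-c1ccccc1`, 18.7%
compound 2, `CCCCCOc1cc(C(=O)N(C)C)nn1-c1ccccc1`, 20%

In a functional assay on the whole organism (strain Wistar) for inhibition, with Rattus norvegicus as the target, read by paw edema, with stated times of 30 min and 3 h, at a dose of 100 mg/kg by the oral route (on this read-out higher numbers stand for more inhibition at the one dose given (going by the name of the read-out) and lower numbers for less inhibition), compound 1 gives 18.7%, and compound 2 gives 20%. Among the measured compounds shown here, the one measured step, a number 1.3 percentage points higher from compound 1 to compound 2 (within the scatter), lies within the scatter. Compound 2 therefore holds the higher of the two numbers only nominally, with compound 1 close enough that no order between them can be claimed.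

Compound 3, `CC(C)CCOc1cc(C(=O)N(C)C)nn1-c1ccccc1`, differs from compound 2 by isopropyl in place of propyl on a saturated chain carbon, two bonds along the chain from an oxygen on an aromatic ring. The step from compound 1 to compound 2 is the only one available, and it concerns chain length rather than branching, so it bears on this change only loosely; what it shows is that a small alteration of the chain left the read-out within the scatter. On that basis compound 3 is expected to give 20%, with a range from 8% to 32%. The step that this estimate means, no change at the digits printed from compound 2 to compound 3 (within the scatter), is expected to stay within the scatter.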

Compound 3, a percentage reported as inhibition, in the whole organism at one dose (the size of the read-out at that dose, not a potency): 25.3%
Estimate against measurement, compound 3: 5.3 percentage points below; low and high end bracket the measured number.
By their numbers in this assay, from the lowest: compounds 1, 2 and 3 (each within the scatter of the next).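

For the branching itself, this assay reads a number 5.3 percentage points higher from compound 2 to compound 3 (within the scatter) when the pentyloxy chain gives way to the isopentyloxy chain, so joining the same atoms differently at this place does not separate the two compounds. Methyl in place of hydrogen on a saturated chain carbon bound to two saturated chain carbons likewise gives a number 6.6 percentage points higher from compound 1 to compound 3 (within the scatter), which shows that the branched chain also cannot be told apart from the chain of compound 1 at the one dose given. Nothing available speaks to the reason for these readings. On these data alone, it remains open whether a longer chain, a cyclohexyl group or an amine at the end of the chain would give a step beyond the scatter on this read-out.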